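The source may report more compounds than this note shows. Statements on the series, on what has been measured and on what is new or still open speak of the compounds shown alone.

Measured compounds:
compound 1 `CC(=O)Nc1c(C(O)(C(F)(F)F)C(F)(F)F)ccc2ccccc12` — 18 nM
compound 2 `O=C(Nc1c(C(O)(C(F)(F)F)C(F)(F)F)ccc2ccccc12)c1ccc(Cl)c(Cl)c1` — 194 nM

In an assay on LtK cells with ATP-sensitive inward rectifier potassium channel 11 (Homo sapiens) as the target (a higher number here means that more compound is needed for the effect, a lower number that less compound is needed), compound 2 holds the higher of the two numbers. Within the data shown here, the single measured step, an 11-fold higher number from compound 1 to compound 2 (1.03 log units; beyond the scatter), shows that exchanging a methyl for an aromatic ring on the carbonyl carbon raised the number markedly. Compound 3 `O=C(Nc1c(C(O)(C(F)(F)F)C(F)(F)F)ccc2ccccc12)c1cccnc1` keeps an aromatic ring there but changes it: pyridin-3-yl in place of 3,4-dichlorophenyl on a carbonyl carbon. Among the measured compounds shown here, no measured pair speaks to this change directly, so an expected step of a 1.5-fold lower number from compound 2 to compound 3 (0.17 log units; within the scatter) is only a rough guess, within the scatter either way. Compound 3 is therefore expected to give about 130 nM in this assay, somewhere between 35 nM and 500 nM.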

Compound 3, half-maximal effective concentration: 60 nM
Compound 3: the middle estimate sits 2.2-fold (0.34 log units) above what was measured, and the stated range covers the measured number.
By their numbers in this assay, from the lowest: compound 1; then compound 3; then compound 2.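

Replacing 3,4-dichlorophenyl with pyridin-3-yl gives a 3.2-fold lower number from compound 2 to compound 3 (0.51 log units; beyond the scatter) in this assay, so the kind of aromatic ring on the carbonyl carbon matters, not only its presence. Methyl still gives the lowest number, since pyridin-3-yl brings a 3.3-fold higher number from compound 1 to compound 3 (0.52 log units; beyond the scatter) as well. Nothing measured here explains these differences.

The change removes both chlorines and adds a ring nitrogen at once, and plain phenyl would be needed to separate the two. From the compounds shown here alone, whether a longer chain such as ethyl would stay close to methyl also remains open.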